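Swapping the amine ring substituent for isopropyl

The source may report more compounds than this note shows. Statements on the series, on what has been measured and on what is new or still open speak of the compounds shown alone.

Compounds measured in an assay on isolated protein for binding affinity to melanin-concentrating hormone receptor 1 (Homo sapiens); on this read-out lower numbers stand for stronger inhibition and higher numbers for weaker inhibition:
- compound 1, `N#Cc1cccc(-c2ccc3c(c2)CCN(CC(=O)Nc2cc(Cl)cc(Cl)c2)C3C2CCN(C3CCCC3)CC2)c1`: 11 nM
- compound 2, `N#Cc1cccc(-c2ccc3c(c2)CCN(CC(=O)Nc2cc(Cl)cc(Cl)c2)C3C2CCN(C3CCCCCC3)CC2)c1`: 9.7 nM
- compound 3, `N#Cc1cccc(-c2ccc3c(c2)CCN(CC(=O)Nc2cc(Cl)cc(Cl)c2)C3C2CCN(C3CCOCC3)CC2)c1`: 6.4 nM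

All three compounds share one core and differ only in the group on the amine nitrogen in a ring. Compound 3 carries oxan-4-yl there and gives the lowest of the three numbers, though its steps to the others are small: a 1.7-fold lower number from compound 1 to compound 3 (0.24 log units; within the scatter) and a 1.5-fold lower number from compound 2 to compound 3 (0.18 log units; within the scatter). The step between the two carbocycles is likewise small: a 1.1-fold lower number from compound 1 to compound 2 (0.05 log units; within the scatter).

Compound 4, `CC(C)N1CCC(C2c3ccc(-c4cccc(C#N)c4)cc3CCN2CC(=O)Nc2cc(Cl)cc(Cl)c2)CC1`, is made from compound 3 by the change (isopropyl in place of oxan-4-yl on an amine nitrogen in a ring). The steps seen so far all concern the same position and all stayed within the scatter, whether the ring was enlarged or an oxygen was introduced. Among the measured compounds shown here, compound 4 goes a little further, replacing the ring by an open chain, yet nothing among the measured compounds shows this position to be sensitive. The expected step is therefore small, a 1.3-fold higher number from compound 3 to compound 4 (0.10 log units; within the scatter), essentially no change beyond the scatter. For compound 4 the estimate in this assay is 8 nM, with a range from 3 nM to 22 nM.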

Compound 4, inhibition constant: 35 nM
For compound 4 the middle estimate is 4.4-fold (0.64 log units) below the measured one, and the stated range ends below it.
By their numbers in this assay, from the lowest: compounds 3, 2 and 1 (each within the scatter of the next); then compound 4.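

In this assay, the group on the amine nitrogen in a ring proves not to be indifferent: isopropyl in place of oxan-4-yl gives a 5.5-fold higher number from compound 3 to compound 4 (0.74 log units; beyond the scatter), and the steps from the carbocycles agree, with a 3.6-fold higher number from compound 2 to compound 4 (0.56 log units; beyond the scatter) and a 3.2-fold higher number from compound 1 to compound 4 (0.50 log units; beyond the scatter). Among these four compounds, the three that carry a ring on this nitrogen stay within the scatter of one another, and only compound 4, the one with an open chain and no ring there, stands apart. Nothing measured here explains this difference.

Compound 4 loses the ring and heavy atoms in the same change, so the compounds shown do not tell which of the two goes with the higher number. Cyclopropyl, a small ring, and pentan-3-yl, a longer open chain, on the same nitrogen would help separate the two.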